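Triazole amide series: a fluoroethoxybenzyl variant on the aromatic nitrogen

The compounds below may be only part of what the source reports. "The series", "measured", "known", "first", "only" and "open" are said of these compounds alone.

Measured in an assay on membranes from brain for displacement of a labelled ligand from Sigma non-opioid intracellular receptor 1 (Cavia porcellus), read by scintillation counting, with a stated time of 90 min; on this read-out lower numbers stand for stronger inhibition and higher numbers for weaker inhibition:
Compound 1 `COc1cccc(-n2cc(C(=O)NCCCCN3CCc4cc(OC)c(OC)cc4C3)nn2)c1`: 20200 nM
Compound 2 `COc1cc2c(cc1OC)CN(CCCCNC(=O)c1c[nH]nn1)CC2`: 11000 nM
Compound 3 `COc1ccc(Cn2cc(C(=O)NCCCCN3CCc4cc(OC)c(OC)cc4C3)nn2)cc1`: 3350 nM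

Compound 3 gives the lowest number of the three. Its lead over compound 2, a 3.3-fold lower number from compound 2 to compound 3 (0.52 log units; beyond the scatter), and over compound 1, a 6.0-fold lower number from compound 1 to compound 3 (0.78 log units; beyond the scatter), are both beyond the scatter, whereas a 1.8-fold lower number from compound 1 to compound 2 (0.26 log units; within the scatter) is within it. Compound 4 `COc1cc2c(cc1OC)CN(CCCCNC(=O)c1cn(Cc3cccc(OCCF)c3)nn1)CC2` differs from compound 3 by 3-(2-fluoroethoxy)phenyl in place of 4-methoxyphenyl on a saturated chain carbon bound to an aromatic nitrogen. The measured steps all concern the same aromatic nitrogen, but each of them exchanges hydrogen or 3-methoxyphenyl for 4-methoxybenzyl; none alters the substituent of the benzyl group itself. Because a 3.3-fold lower number from compound 2 to compound 3 (0.52 log units; beyond the scatter) and a 6.0-fold lower number from compound 1 to compound 3 (0.78 log units; beyond the scatter) favour the benzyl over its alternatives, compound 4 is expected to keep that level, with no step beyond the scatter in this assay expected from compound 3 to compound 4, a 1.2-fold lower number from compound 3 to compound 4 (0.09 log units; within the scatter). For compound 4 the estimate is 2700 nM, between 800 nM and 9000 nM.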

Compound 4, inhibition constant: 46300 nM
Compound 4: middle estimate off by 17-fold (1.23 log units), on the low side; measured number above the stated range.
By their numbers in this assay, from the lowest: compound 3; then compounds 2 and 1 (each within the scatter of the next); then compound 4.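

In this assay, this position proves sensitive to what the benzyl group carries, not only to whether a benzyl group is present: 3-(2-fluoroethoxy)benzyl in place of 4-methoxybenzyl costs a large step (a 14-fold higher number from compound 3 to compound 4 (1.14 log units; beyond the scatter)). The new group also reads worse than hydrogen (a 4.2-fold higher number from compound 2 to compound 4 (0.62 log units; beyond the scatter)) and than 3-methoxyphenyl (a 2.3-fold higher number from compound 1 to compound 4 (0.36 log units; beyond the scatter)) on the aromatic nitrogen, so a benzyl group alone does not secure a gain. No measurement at hand explains this loss.

From the compounds shown here alone, how 3-methoxybenzyl or 4-(2-fluoroethoxy)benzyl would read stays open, and with it which part of the change carries the loss. Also open, going by these compounds, is a benzyl group bearing an amine.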